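Adding an Isopropyl Group to the Anilino Ring of Compound 3

A few compounds are considered here, and "the series" means these few. Any claim that something is new, unique, unknown or untested is made for them only; others in the source may bear on it.

Compound 3 `CC(C)c1ccc(-c2nc(SCc3cn(CC(=O)NC(=O)Nc4ccccn4)nn3)nc(Nc3ccccc3)c2C#N)cc1` sits at the edge of what a functional assay on MCF7 cells (Homo sapiens) for inhibition, read by MTT assay, with a stated time of 72 h (on this read-out higher numbers stand for weaker inhibition and lower numbers for stronger inhibition), can report: in this assay compound 3 reports > 64000 nM, which is a limit rather than a number. Compound 1 `CC(C)c1ccc(-c2nc(SCc3cn(CC(=O)NC(=O)Nc4ccccn4)nn3)nc(Nc3cccc(Cl)c3)c2C#N)cc1` gives 18000 nM, and compound 2 `CC(C)c1ccc(-c2nc(SCc3cn(CC(=O)NC(=O)Nc4ccccn4)nn3)nc(Nc3cccc([N+](=O)[O-])c3)c2C#N)cc1` gives 25900 nM. Compound 4 `CC(C)c1ccc(Nc2nc(SCc3cn(CC(=O)NC(=O)Nc4ccccn4)nn3)nc(-c3ccc(C(C)C)cc3)c2C#N)cc1` differs from compound 3 by isopropyl in place of hydrogen on an aromatic carbon, placed on an aromatic carbon of a six-membered aromatic ring of carbon only, para to a large group. For the measured compounds named here, no measured step adds a group to that ring; the nearest are an at least 3.5-fold higher number from compound 1 to compound 3 (0.55 log units; beyond the scatter) and an at least 2.4-fold higher number from compound 2 to compound 3 (0.39 log units; beyond the scatter), in which a group leaves the same ring and the number rises at least modestly. A step of comparable size in the opposite direction is therefore expected, though a limit remains possible (the limit of > 64000 nM in this assay, at which 1 of the 3 values shown sits). Compound 4 is estimated at 45000 nM (range 15000 nM to 150000 nM), an expected step of an at least 1.4-fold lower number from compound 3 to compound 4 (0.15 log units; that floor lies within the scatter).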

Compound 4, half-maximal inhibitory concentration: 28600 nM
Beside the measured number, compound 4's estimate is 1.6-fold (0.20 log units) above it, and the stated range covers the measured number.
By their numbers in this assay, from the lowest: compounds 1, 2 and 4 (each within the scatter of the next). At a limit, above all of these: compound 3.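

In this assay, isopropyl on the anilino ring, para to a large group, gives a step of its own, an at least 2.2-fold lower number from compound 3 to compound 4 (0.34 log units; beyond the scatter), so a carbon group on this ring serves as well as the chloro and nitro groups did. Exchanging the whole aryl group gives a 1.1-fold higher number from compound 2 to compound 4 (0.04 log units; within the scatter) and a 1.6-fold higher number from compound 1 to compound 4 (0.20 log units; within the scatter), so 4-isopropylphenyl cannot be told apart from 3-nitrophenyl or 3-chlorophenyl here. Compound 3 remains a limit, so the step from it is only a floor: the limit of > 64000 nM in this assay, at which 1 of the 4 values shown sits.

As far as these compounds go, whether an amine or a methoxy group on that carbon would behave like isopropyl stays open. So does whether a longer alkyl chain would lower the number further.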